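Swapping One Halogen at the Edge of Compound 3

The source may report more compounds than this note shows. Statements on the series, on what has been measured and on what is new or still open speak of the compounds shown alone.

In a functional assay on MCF7 cells (Homo sapiens) for cytotoxicity, read by sulforhodamine B assay, with a stated time of 48 h (a lower number here means a stronger inhibitor of growth, a higher number a weaker inhibitor of growth), the three measured compounds lie close together. Compound 1 `O=C1C(=O)N(CN2CCN(c3ccnc4cc(Cl)ccc34)CC2)c2cc(Br)ccc21` gives 17600 nM, compound 2 `O=C1C(=O)N(CN2CCN(c3ccnc4cc(C(F)(F)F)ccc34)CC2)c2ccccc21` gives 34000 nM, and compound 3 `NC(=S)N/N=C1/C(=O)N(CN2CCN(c3ccnc4cc(Cl)ccc34)CC2)c2cccc(Cl)c21` gives 57500 nM, the highest of the three numbers. The gap between compound 3 and compound 2 lies within the usual scatter, so the two cannot be ordered, whereas the gap to compound 1 lies beyond it. Compound 4 `NC(=S)N/N=C1/C(=O)N(CN2CCN(c3ccnc4cc(Cl)ccc34)CC2)c2cccc(Br)c21` differs from compound 3 by bromo in place of chloro on an aromatic carbon. Among the measured compounds shown here, no measured pair shows the effect of this exchange, so no shift beyond the scatter is expected in this assay. Compound 4 is therefore estimated at 55000 nM, with a likely range from 25000 nM to 120000 nM. The expected step is a 1.0-fold lower number from compound 3 to compound 4 (0.02 log units; within the scatter), leaving the two compounds within the scatter of each other.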

Compound 4, concentration for 50% growth inhibition: 46600 nM
Compound 4: middle estimate off by 1.2-fold (0.07 log units), on the high side, within the range that was stated.
By their numbers in this assay, from the lowest: compounds 1, 2, 4 and 3 (each within the scatter of the next, the first and the last beyond it).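

In this assay, among the compounds shown here, the change gives a 1.2-fold lower number from compound 3 to compound 4 (0.09 log units; within the scatter), the first measured pair to test this aromatic carbon, and it shows that bromo and chloro cannot be told apart here. This holds only for this exchange on the core of compound 3, in this one cell assay. Nothing measured here offers an explanation for this result.

As far as these compounds go, whether fluoro, methoxy or an amine on the same aromatic carbon would stay within the scatter of compound 3 remains open. Also open, from the compounds shown here alone, is whether a bare hydrogen there would do so.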